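Aromatic Acid Tail in Place of a Chain Acid Tail

The compounds below may be only part of what the source reports. "The series", "measured", "known", "first", "only" and "open" are said of these compounds alone.

Measured so far:
Compound 1 `O=C(O)CCC(=O)OCCCOc1no[n+]([O-])c1S(=O)(=O)c1ccccc1` gives > 10000 nM, a limit of the assay.
Compound 2 `O=C(O)CCCC(=O)OCCCOc1no[n+]([O-])c1S(=O)(=O)c1ccccc1` gives > 10000 nM, a limit of the assay.

In a functional assay on HT-29 cells (Homo sapiens) for antiproliferative activity, read by MTT assay, with a stated time of 72 h (on this read-out lower numbers stand for stronger inhibition and higher numbers for weaker inhibition), compound 2 gives > 10000 nM, which is a limit of the assay and not a number. Compound 1 gives only a limit too. For the measured compounds named here, the single measured step, a step that the two limits leave unreadable from compound 1 to compound 2, therefore cannot be read in size or direction. Compound 3 `O=C(O)c1ccccc1C(=O)OCCCOc1no[n+]([O-])c1S(=O)(=O)c1ccccc1` differs from compound 2 by 2-carboxyphenyl in place of 3-carboxypropyl on a carbonyl carbon. Going by the values given here, no measured step bears directly on this change. What the data do show is that both measured compounds sit at the same limit (the limit of > 10000 nM in this assay, at which 2 of the 2 values shown sit). Compound 3 is therefore expected to remain at or near that limit, and the step that the limit leaves unreadable from compound 2 to compound 3 is expected to be nothing readable beyond the scatter. The estimate for compound 3 in this assay is 15000 nM, with a range from 5000 nM to 50000 nM, most likely reported again as a limit.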

Compound 3, half-maximal inhibitory concentration: > 10000 nM
Compound 3 ended at the assay's limit (the forecaster's own chance of this, stated with the estimate: 85%); the middle value is on the limit's open side.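

For the compounds shown here, compound 3 sits at a limit of the assay, as do compound 1 and compound 2, so no step among the three can be read: the limit of > 10000 nM in this assay, at which 3 of the 3 values shown sit. The compounds shown leave open whether 2-carboxyphenyl, 3-carboxypropyl and 2-carboxyethyl differ at all in their effect on these cells.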